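Swapping piperidinyl for an arylamine on a shared core

The compounds below may be only part of what the source reports. "The series", "measured", "known", "first", "only" and "open" are said of these compounds alone.

Compound 1, with the structure `O=C1C(N2CCCCC2)=CC(=O)c2c1nc1n2[C@H]2OC[C@@H](O)[C@H]2OC1`, carries a piperidin-1-yl group on a double-bonded ring carbon of its core. In a functional assay on MGC-803 cells (Homo sapiens) for inhibition, read by sulforhodamine B assay (on this read-out lower numbers stand for stronger inhibition and higher numbers for weaker inhibition), compound 1 gives only a limit of the assay, > 4000 nM, and not a number. Two neighbours on the same core carry an arylamino group at that carbon instead. Compound 2, `CCOc1ccccc1NC1=CC(=O)c2nc3n(c2C1=O)[C@H]1OC[C@@H](O)[C@H]1OC3`, gives 2450 nM in this assay. Compound 3, `O=C1C=C(Nc2ccc(Br)cc2)C(=O)c2c1nc1n2[C@H]2OC[C@@H](O)[C@H]2OC1`, gives 1010 nM. Going by the values given here, the one measured step, a 2.4-fold lower number from compound 2 to compound 3 (0.38 log units; beyond the scatter), shows that the arylamino compounds sit close together, with the 4-bromophenyl member giving the lower number. Compound 4, `CCc1ccc(NC2=CC(=O)c3c(nc4n3[C@H]3OC[C@@H](O)[C@H]3OC4)C2=O)cc1`, has not yet been measured. It differs from compound 1 by (4-ethylphenyl)amino in place of piperidin-1-yl on a double-bonded ring carbon. Among the compounds with values here, no measured step covers this exact exchange, since compound 1 sits at the limit (the limit of > 4000 nM in this assay, at which 1 of the 3 values shown sits). Compound 2 and compound 3 show that arylamino members of this series give numbers well inside the measured range, so compound 4 is expected to land near them. For compound 4 the expected value is 1200 nM, with a range from 500 nM to 3000 nM. This would mean an expected step of an at least 3.3-fold lower number from compound 1 to compound 4 (0.52 log units; beyond the scatter), toward the stronger side.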

Compound 4, half-maximal inhibitory concentration: 1110 nM
Estimate against measurement, compound 4: 1.1-fold (0.03 log units) above, within the range that was stated.
By their numbers in this assay, from the lowest: compounds 3 and 4 (each within the scatter of the next); then compound 2. At a limit, above all of these: compound 1.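

In this assay, going by these compounds alone, the first measured step for replacing piperidin-1-yl with an arylamino group on a double-bonded ring carbon points toward the stronger side: an at least 3.6-fold lower number from compound 1 to compound 4 (0.55 log units; beyond the scatter). Compound 4 gives 1110 nM and compound 3 gives 1010 nM, two values within the usual scatter of each other, so (4-ethylphenyl)amino and the 4-bromophenyl member cannot be told apart at this position in this assay. On these data alone, the true size of the step from the piperidine compound remains unknown, since its starting point is a limit and not a number: the limit of > 4000 nM in this assay, at which 1 of the 4 values shown sits.

This single exchange replaces a non-aromatic ring with an aromatic one and also adds a hydrogen-bond donor, so the compounds shown cannot say which of these differences goes with the lower number. A benzylamino group, which keeps the amine hydrogen and places a carbon between the nitrogen and the aromatic ring, and a morpholin-4-yl group, which keeps a non-aromatic ring but adds an oxygen, would each test a different part of that question at this carbon.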